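This account rests on a few compounds, and the source may have more. Where it says the series, first, only, none or still open, it means among the compounds named here.

Measured compounds:
Compound 1 `CCOC(=O)c1c(C)coc1-c1ccc2c(CC)cccc2c1OC`: 2.2 ug/mL
Compound 2 `CCc1cccc2c(OC(C)=O)c(-c3occ(C)c3COC(C)=O)ccc12`: > 10 ug/mL

Going by the values given here, compound 1 carries the only numerical reading in a functional assay on KB cells (Homo sapiens) for cytotoxicity, read by MTT assay, with a stated time of 72 h (on this read-out higher numbers stand for an effect only at larger amounts of compound and lower numbers for an effect already at smaller amounts), where compound 1 gives 2.2 ug/mL. For compound 2 the value in this assay is a limit, > 10 ug/mL, not a number. The set thus contains (the limit of > 10 ug/mL in this assay, at which 1 of the 2 values shown sits). Compound 3 `CCc1cccc2c(OC)c(-c3occ(C)c3COC(C)=O)ccc12` is the next compound to be measured in this assay. It differs from compound 1 in one place: acetoxymethyl in place of ethoxycarbonyl on an aromatic carbon. Compound 3 shares its acetoxymethyl group with compound 2, whose reading in this assay was only a limit, > 10 ug/mL, while compound 1, with ethoxycarbonyl at the same position, gives 2.2 ug/mL. The step of a 2.7-fold higher number from compound 1 to compound 3 (0.44 log units; beyond the scatter) is therefore expected to go toward weaker cytotoxicity, beyond the usual scatter. Compound 3 is estimated at 6 ug/mL in this assay, within a range from 2.5 ug/mL to 15 ug/mL.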

Compound 3, concentration for half-maximal effect: > 10 ug/mL
Compound 3 gave a limit, no number; the forecaster's own chance of this, stated with the estimate: 35%; middle value at least 1.6-fold (0.22 log units) away from the limit.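

Compound 3 has the same atoms as compound 1 and differs from it only in acetoxymethyl in place of ethoxycarbonyl on this aromatic carbon of the five-membered ring, so it isolates a change that compound 2 could not, as compound 2 also differs on the oxygen. In this assay this single change gives an at least 4.5-fold higher number from compound 1 to compound 3 (0.65 log units; beyond the scatter), and the size of that step is only a lower bound, as the reading of compound 3 is a limit, not a number. The step between compound 2 and compound 3 cannot be read, and the set now rests largely on one ceiling: the limit of > 10 ug/mL in this assay, at which 2 of the 3 values shown sit.

From the compounds shown here alone, how far the true value of compound 3 lies past that limit remains open. So does whether a carboxylic acid or a hydroxymethyl group at this position would read closer to compound 1, and whether acetyl on the oxygen would matter with ethoxycarbonyl kept in place.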